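Benzyl piperazine arm: trifluoromethyl to cyano swap

The compounds below may be only part of what the source reports. "The series", "measured", "known", "first", "only" and "open" are said of these compounds alone.

The series shares one core carrying a piperazine amide chain; the compounds differ only in the group on the distal piperazine nitrogen. Compound 1 `CCN(CC)c1ccc2cc(C(=O)c3ccc(N4CCN(C(=O)CN5CCN(C(=O)CCl)CC5)CC4)cc3)oc2c1` carries a (chloromethyl)carbonyl there, and in a functional assay on HeLa cells (Homo sapiens) for cytotoxicity, read by MTT assay, with a stated time of 48 h (on this read-out lower numbers stand for stronger inhibition and higher numbers for weaker inhibition), compound 1 gives 5520 nM. Compound 2 `CCN(CC)c1ccc2cc(C(=O)c3ccc(N4CCN(C(=O)CN5CCN(C(=O)/C=C/c6ccccc6)CC5)CC4)cc3)oc2c1` carries a (2-phenylethenyl)carbonyl, and in this assay compound 2 gives 5260 nM; the step of a 1.0-fold lower number from compound 1 to compound 2 (0.02 log units; within the scatter) is within the scatter. Compound 3 `CCN(CC)c1ccc2cc(C(=O)c3ccc(N4CCN(C(=O)CN5CCN(Cc6ccc(C(F)(F)F)cc6)CC5)CC4)cc3)oc2c1` carries a 4-(trifluoromethyl)benzyl instead. For compound 3 this assay reports only a limit, > 40000 nM, as recorded in the limit of > 40000 nM in this assay, at which 1 of the 3 values shown sits. Against both acyl compounds this is a loss: an at least 7.2-fold higher number from compound 1 to compound 3 (0.86 log units; beyond the scatter) and an at least 7.6-fold higher number from compound 2 to compound 3 (0.88 log units; beyond the scatter), each beyond the scatter, so compound 3 stands at the weak end of the three measured compounds.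

Compound 4 `CCN(CC)c1ccc2cc(C(=O)c3ccc(N4CCN(C(=O)CN5CCN(Cc6ccc(C#N)cc6)CC5)CC4)cc3)oc2c1` keeps the benzyl arm and changes only its substituent: cyano in place of trifluoromethyl on an aromatic carbon. Within the data shown here, no measured step touches this substituent; the two steps that lead to compound 3 concern the benzyl replacing an acyl group, and compound 4 retains the benzyl. The expected outcome in this assay is therefore no step beyond the scatter, a number no higher from compound 3 to compound 4 (the limit leaves the size open). Compound 4 is estimated at 40000 nM, range 12000 nM to 120000 nM, and most likely will again be reported only as a limit.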

Compound 4, half-maximal inhibitory concentration: > 40000 nM
Compound 4 ended at the assay's limit; the forecaster's own chance of this, stated with the estimate: 65%; the middle value lies on the limit itself.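

In this assay compound 4 gives > 40000 nM, which is a limit of the assay and not a number. The loss against the acyl arms therefore does not depend on trifluoromethyl alone, as a benzyl arm carrying cyano shows the same drop: an at least 7.6-fold higher number from compound 2 to compound 4 (0.88 log units; beyond the scatter) and an at least 7.2-fold higher number from compound 1 to compound 4 (0.86 log units; beyond the scatter), both beyond the scatter. The step between the two benzyl compounds, compound 3 and compound 4, cannot be read, so this position shows no difference between cyano and trifluoromethyl, and any such difference would lie out of sight past the limit: the limit of > 40000 nM in this assay, at which 2 of the 4 values shown sit.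

From the compounds shown here alone, whether an amine or a carboxylic acid in place of the cyano would bring a benzyl compound back into the measurable range remains open. Also open, going by these compounds, is whether the drop comes from the benzyl ring arm itself or from the loss of the carbonyl on that piperazine nitrogen, a question that a benzoyl group, which keeps both the carbonyl and a phenyl ring, would bear on directly.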